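A few compounds are considered here, and "the series" means these few. Any claim that something is new, unique, unknown or untested is made for them only; others in the source may bear on it.

Compound 1, whose structure is `COc1cccc(C#Cc2cc(Cl)cn3c([N+](=O)[O-])c(CS(=O)(=O)c4ccccc4)nc23)c1`, was tested in an ADME assay on HepG2 cells (Homo sapiens) for cytotoxicity, read by MTT assay, with a stated time of 72 h; on this read-out higher numbers stand for lower toxicity in this test and lower numbers for higher toxicity in this test. In this assay compound 1 gives > 3900 nM, which is a limit of the assay rather than a measured number. Compound 2, with structure `COc1ccccc1C#Cc1cc(Cl)cn2c([N+](=O)[O-])c(CS(=O)(=O)c3ccccc3)nc12`, gives > 3900 nM, again a limit. Compound 3, with structure `O=[N+]([O-])c1c(CS(=O)(=O)c2ccccc2)nc2c(C#Cc3cccc(F)c3)cc(Cl)cn12`, gives > 3900 nM, also a limit. Because all three values sit at the limit of > 3900 nM in this assay, at which 3 of the 3 values shown sit, the steps among them cannot be read: a step that the two limits leave unreadable from compound 1 to compound 2, a step that the two limits leave unreadable from compound 1 to compound 3 and a step that the two limits leave unreadable from compound 2 to compound 3 all stay hidden behind the same boundary.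

Compound 4, whose structure is `O=[N+]([O-])c1c(CS(=O)(=O)c2ccccc2)nc2c(C#CC3(O)CCCC3)cc(Cl)cn12`, differs from compound 1 in one place: 1-hydroxycyclopentyl in place of 3-methoxyphenyl on a triple-bonded carbon. Going by the values given here, none of the measured steps bears directly on this change, and each of them is unreadable, so the size of the step cannot be expected from the numbers at hand. What the three compounds do share is the limit itself, so the most likely outcome is that compound 4 also stays at or beyond it. Compound 4 is therefore estimated at 6000 nM, ranging from 2500 nM to 20000 nM. This estimate implies a step that the limit leaves unreadable from compound 1 to compound 4, expected to lie within the usual scatter.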

Compound 4, half-maximal cytotoxic concentration: > 31300 nM
Compound 4: a limit, no number; the forecaster's own chance of this, stated with the estimate: 75%; middle value at least 5.2-fold (0.71 log units) from the limit.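

In this assay compound 4 gives > 31300 nM, which is a limit and not a number. Going by these compounds alone, compound 1, compound 2 and compound 3 also stand at limits, so no step to compound 4 can be read. The compounds shown leave open at what concentration any of the four becomes toxic to these cells.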